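The compounds below may be only part of what the source reports. "The series", "measured", "known", "first", "only" and "open" are said of these compounds alone.

Measured compounds:
- Compound 1, `O=C(Nc1ccccc1)Nc1ccc(S(=O)(=O)Nc2ccnc3cc(C(F)(F)F)ccc23)cc1`: in a functional assay on AS49-RAW cells (Homo sapiens) for antiproliferative activity, read by sulforhodamine B assay, with a stated time of 48 h (a higher number here means a weaker inhibitor, a lower number a stronger inhibitor), compound 1 gives 24500 nM
- Compound 2, `N=C(N)NS(=O)(=O)c1ccc(N/C(S)=N\c2ccnc3cc(C(F)(F)F)ccc23)cc1`: in this assay compound 2 gives 23900 nM

Compound 2 has the lower of the two numbers, but its nearest neighbour, compound 1, sits within the scatter of it, so the two are best read as equal. Both share a core with a trifluoromethyl group, and both are weak inhibitors in this assay.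

Compound 3, `O=S(=O)(Nc1nccs1)c1ccc(N/C(S)=N\c2ccnc3cc(C(F)(F)F)ccc23)cc1`, has not yet been measured. It differs from compound 2 in one place: a group of 5 heavy atoms (3 carbon, 1 nitrogen, 1 sulfur; one five-membered aromatic ring with 2 hetero atoms) in place of a group of 3 heavy atoms (1 carbon, 2 nitrogen; no ring), on a sulfonamide nitrogen. The rest of the structure, including the thiourea link to the shared core, is unchanged.

For the measured compounds named here, no measured pair shows what this exchange on the sulfonamide nitrogen does, so there is no basis for expecting a step beyond the scatter in either direction. The step from compound 2 to compound 3 is therefore estimated to be small, a 1.2-fold lower number from compound 2 to compound 3 (0.08 log units; within the scatter). Compound 3 is expected to give about 20000 nM in this assay, with a range from 7000 nM to 60000 nM.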

Compound 3, half-maximal inhibitory concentration: 27200 nM
Compound 3: middle estimate off by 1.4-fold (0.13 log units), on the low side; the range from low to high includes it.
By their numbers in this assay, from the lowest: compounds 2, 1 and 3 (each within the scatter of the next).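

In this assay the exchange on the sulfonamide nitrogen gives a 1.1-fold higher number from compound 2 to compound 3 (0.06 log units; within the scatter) and so the two compounds are best read as equal. For the compounds shown here, this is the first measured pair that differs in one place, and it shows that a 1,3-thiazol-2-yl ring can take the place of the open, ring-free group of compound 2 on this nitrogen without a step beyond the scatter. The exchange is not a small one on paper, since the entering ring has more heavy atoms, 0 hydrogen-bond donors and 2 hydrogen-bond acceptors, while the leaving group has 2 donors and 1 acceptor, yet nothing measured here gives a reason for the lack of a clear step.

Going by these compounds, whether a methyl group, a simple amine chain or a carboxylic acid chain on this nitrogen would give a number like these remains open. Going by these compounds alone, it is also open whether any group at this place can move the number beyond the scatter at all, since only one exchange here can be read and both compounds in it are weak inhibitors.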